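Swapping the Aryl Group on the Sulfonyl Sulfur

The compounds below may be only part of what the source reports. "The series", "measured", "known", "first", "only" and "open" are said of these compounds alone.

In a functional assay on MIA PaCa-2 cells (Homo sapiens) for inhibition, read by MTT assay, with a stated time of 72 h (a higher number here means a weaker inhibitor of growth, a lower number a stronger inhibitor of growth), compound 2 `O=S(=O)(NCCCCCCNCc1ccc(Br)cc1)c1ccc2c(c1)OCC2` gives 13000 nM; compound 1 `O=[N+]([O-])c1ccc(S(=O)(=O)NCCCCCCNCc2ccc(Br)cc2)cc1` gives 9800 nM, and the gap between them is within the scatter, so compound 2 stands at one end of two numbers that cannot be told apart. Compound 3 `O=S(=O)(NCCCCCCNCc1ccc(Br)cc1)c1ccccc1F` differs from compound 2 by a group of 7 heavy atoms (6 carbon, 1 fluorine; one six-membered aromatic ring of carbon only) in place of a group of 9 heavy atoms (8 carbon, 1 oxygen; one five-membered non-aromatic ring with 1 hetero atom, one six-membered aromatic ring of carbon only), on a sulfonyl sulfur. Among the compounds with values here, the only measured step that bears on this, another exchange at the same sulfonyl sulfur, was a 1.3-fold higher number from compound 1 to compound 2 (0.12 log units; within the scatter). For compound 3 the expected step is therefore a 1.2-fold lower number from compound 2 to compound 3 (0.07 log units; within the scatter), nothing beyond the scatter. Compound 3 is estimated at 11000 nM, with a range from 4500 nM to 27000 nM.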

Compound 3, concentration for 50% growth inhibition: 13300 nM
Compound 3: middle estimate off by 1.2-fold (0.08 log units), on the low side, and the stated range covers the measured number.
By their numbers in this assay, from the lowest: compounds 1, 2 and 3 (each within the scatter of the next).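

In this assay, replacing the earlier groups with 2-fluorophenyl gives a 1.0-fold higher number from compound 2 to compound 3 (0.01 log units; within the scatter), and, against 4-nitrophenyl, a 1.4-fold higher number from compound 1 to compound 3 (0.13 log units; within the scatter). Three different groups on this sulfonyl sulfur therefore give numbers that cannot be told apart, so none of these exchanges has yet shown this position to matter for growth inhibition. No measurement is available to explain this result.

As far as these compounds go, whether a carboxylic acid or an amine on the sulfonyl sulfur would move the number beyond the scatter remains open. So does the effect of a longer chain in the shared core.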